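Halogen and hydroxy steps applied to compound 4

A few compounds are considered here, and "the series" means these few. Any claim that something is new, unique, unknown or untested is made for them only; others in the source may bear on it.

Compound 3 `O=C(CSc1nnc(-c2ccncc2)n1-c1ccccc1)N/N=C/c1ccc(Cl)cc1` gives 5740 nM in a functional assay on HCT-116 cells (Homo sapiens) for inhibition, read by MTT assay, with a stated time of 48 h (on this read-out higher numbers stand for weaker inhibition and lower numbers for stronger inhibition), and stands lowest of the two numbers in hand. Compound 1 `O=C(CSc1nnc(-c2ccncc2)n1-c1ccccc1)N/N=C/c1ccccc1` is the nearest with 14700 nM, and the gap a 2.6-fold lower number from compound 1 to compound 3 (0.41 log units; beyond the scatter) lies beyond the scatter. Compound 2 `O=C(CSc1nnc(-c2ccncc2)n1-c1ccccc1)N/N=C/c1ccc(O)cc1` reports no number but a limit of the assay, > 50000 nM, that is, (the limit of > 50000 nM in this assay, at which 1 of the 3 values shown sits).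

Compound 4 `O=C(CSc1nnc(-c2ccncc2)n1-c1ccccc1)N/N=C/c1cc(Br)ccc1O` carries the change (5-bromo-2-hydroxyphenyl in place of 4-chlorophenyl on a carbon with a double bond to nitrogen). Among the compounds with values here, three measured steps bear on it. A halogen on the ring lowered the number, a 2.6-fold lower number from compound 1 to compound 3 (0.41 log units; beyond the scatter); a hydroxy raised it to the limit, an at least 3.4-fold higher number from compound 1 to compound 2 (0.53 log units; beyond the scatter); and exchanging one for the other gave an at least 8.7-fold lower number from compound 2 to compound 3 (0.94 log units; beyond the scatter). Within the data shown here, compound 4 holds both a halogen and a hydroxy, the halogen now bromine and the hydroxy at a different position from that of compound 2, so the earlier steps transfer only loosely. The hydroxy effect was the larger one, and the number for compound 4 is therefore expected to move upward from compound 3 by about a 2.6-fold higher number from compound 3 to compound 4 (0.42 log units; beyond the scatter), with a real chance that only a limit is reported.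

Compound 4 is estimated at 15000 nM, with a range from 5000 nM to 50000 nM.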

Compound 4, half-maximal inhibitory concentration: 1990 nM
For compound 4 the middle estimate is 7.5-fold (0.88 log units) above the measured one, outside the stated range (below it).
By their numbers in this assay, from the lowest: compound 4; then compound 3; then compound 1. At a limit, above all of these: compound 2.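

In this assay, a hydroxy on the ring at this carbon with a double bond to nitrogen does not by itself weaken the read-out: 5-bromo-2-hydroxyphenyl gives a 7.4-fold lower number from compound 1 to compound 4 (0.87 log units; beyond the scatter), and in place of 4-chlorophenyl it gives a 2.9-fold lower number from compound 3 to compound 4 (0.46 log units; beyond the scatter). Compound 2 stands at a limit of the assay, so the step of an at least 25-fold lower number from compound 2 to compound 4 (1.40 log units; beyond the scatter) is a bound and not a measured size. Hydroxy-bearing rings now occupy both ends of the series, with compound 4 lowest and compound 2 at the limit, so the hydroxy step read from compound 2 does not carry over to compound 4.

Going by these compounds, in compound 4 the bromo and the hydroxy enter in a single step, and their separate shares, as well as the part played by where each sits, stay open. Also open, on these data alone, is whether a methoxy in place of the hydroxy, or an amine or a carboxylic acid on this ring, would keep the lower number.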